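The source may hold more compounds than are shown below. What is called first, only, known or untested is meant among the compounds shown, and "the series" means these compounds.

Measured so far in a functional assay on A549 cells (Homo sapiens) for antiproliferative activity, read by MTT assay, with a stated time of 72 h; a higher number here means a weaker inhibitor, a lower number a stronger inhibitor:
- Compound 1 `COc1cccc(N2C(=O)COc3ccc(-c4cnc(Cl)c(NS(=O)(=O)c5ccc(F)cc5)c4)cc32)c1`: 32700 nM
- Compound 2 `O=C1COc2ccc(-c3cccc(NS(=O)(=O)c4ccc(F)cc4)c3)cc2N1`: 32100 nM

Only these two compounds have numbers, so the series offers little to go on. In this assay, compound 2 gives 32100 nM and compound 1 gives 32700 nM, and these two values lie within the scatter of each other. Compound 3 `O=C1COc2ccc(-c3cccc(NS(=O)(=O)c4ccc(F)cc4)c3)cc2N1c1ccccc1` is the next to be tested. It differs from compound 2 by phenyl in place of hydrogen on an amide-type nitrogen in a ring. For the measured compounds named here, no measured single-place step exists to scale this change. The two close values, compound 2 at 32100 nM and compound 1 at 32700 nM, give no sign of a large effect, so a small step is expected, leaning slightly towards a lower number and probably not beyond the scatter. The expected change is a 1.5-fold lower number from compound 2 to compound 3 (0.16 log units; within the scatter). For compound 3 the estimated value is 22000 nM, with an expected range of 7000 nM to 60000 nM.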

Compound 3, half-maximal inhibitory concentration: > 40000 nM
Compound 3 ended at the assay's limit; the forecaster's own chance of this, stated with the estimate: 15%; middle value at least 1.8-fold (0.25 log units) away from the limit.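

In this assay, phenyl in place of hydrogen on the amide-type nitrogen in a ring gives the series its first single-place step: an at least 1.2-fold higher number from compound 2 to compound 3 (0.09 log units; that floor lies within the scatter). This shows that, in this pair, the phenyl brought no lower number at this position, although the floor of the step does not establish a loss beyond the scatter. Compound 3 stands at a limit of the assay, so only that floor can be read and the true size of the step stays unknown: the limit of > 40000 nM in this assay, at which 1 of the 3 values shown sits.

The compounds shown leave open how far the number rises with phenyl at this nitrogen. They also leave open whether a methyl group or an aminoethyl chain in the same place would move the number in either direction.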